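Ethoxy for Nitro on the Benzyl Ether: Expected Potency

A few compounds are considered here, and "the series" means these few. Any claim that something is new, unique, unknown or untested is made for them only; others in the source may bear on it.

Compound 2 `COc1cccc(OC)c1OCCNCCOc1ccccc1OCc1ccccc1[N+](=O)[O-]` gives 8.95 in a functional assay on thoracic aorta for antagonist activity at Alpha-1D adrenergic receptor (Rattus norvegicus) (on this read-out lower numbers stand for lower potency and higher numbers for higher potency (the scale is a negative logarithm)), the highest of the three numbers; compound 3 `COc1ccccc1COc1ccccc1OCCNCCOc1c(OC)cccc1OC` sits within the scatter of it at 8.86, while compound 1 `COc1cccc(OC)c1OCCNCCOc1ccccc1OCc1ccccc1Cl` lies further off at 8.59. The measured steps each trade one group on an aromatic carbon: a number 0.36 log units higher from compound 1 to compound 2 (beyond the scatter) and a number 0.09 log units lower from compound 2 to compound 3 (within the scatter), so chloro, nitro and methoxy in that position leave the read-out nearly unchanged. Compound 4 `CCOc1ccc(COc2ccccc2OCCNCCOc2c(OC)cccc2OC)cc1` has not yet been measured; its change is 4-ethoxyphenyl in place of 2-nitrophenyl on a saturated chain carbon bound to an oxygen on an aromatic ring. Because a number 0.09 log units lower from compound 2 to compound 3 (within the scatter) was small and a number 0.36 log units higher from compound 1 to compound 2 (beyond the scatter) only modest, compound 4 is expected to differ little from compound 2 in this assay. The expected shift is a number 0.25 log units lower from compound 2 to compound 4 (within the scatter). The estimate for compound 4 is 8.7, spanning 8.2 to 9.2.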

Compound 4, negative logarithm of the antagonist equilibrium constant: 9.11
Compound 4: the middle estimate sits 0.41 log units below what was measured; measured number inside the range.
By their numbers in this assay, from the lowest: compounds 1, 3, 2 and 4 (each within the scatter of the next, the first and the last beyond it).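

In this assay, 4-ethoxyphenyl on this saturated chain carbon matches 2-nitrophenyl and 2-methoxyphenyl, with a number 0.16 log units higher from compound 2 to compound 4 (within the scatter) and a number 0.25 log units higher from compound 3 to compound 4 (within the scatter). Only against 2-chlorophenyl does the swap stand out, with a number 0.52 log units higher from compound 1 to compound 4 (beyond the scatter). Among these compounds, the position therefore accepts an ethoxy group at the 4-position of the phenyl ring, not just the groups carried by the 2-substituted rings of the earlier compounds.

Nothing available explains this tolerance. Still open, as far as these compounds go, are how 2-ethoxyphenyl would compare with 4-ethoxyphenyl, and whether a phenyl ring bearing an amine or a carboxylic acid would fit here.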